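Fluoro for methoxy on a ring carbon of compound 2

The source may hold more compounds than are shown below. What is called first, only, known or untested is meant among the compounds shown, and "the series" means these compounds.

Compound 2 `COc1ccc(S(=O)(=O)c2nc3ccccc3nc2Nc2cccc(N)c2)cc1` shares its core with compound 1 `COc1ccc(S(=O)(=O)c2nc3ccccc3nc2Nc2cc(OC)cc(OC)c2)cc1`. In a functional assay on PC-3 cells (Homo sapiens) for cytotoxicity, read by MTT assay, with a stated time of 72 h (on this read-out higher numbers stand for weaker inhibition and lower numbers for stronger inhibition), compound 1 gives 6220 nM, and in this assay compound 2 gives 8600 nM. For the measured compounds named here, the one step measured so far, a 1.4-fold higher number from compound 1 to compound 2 (0.14 log units; within the scatter), concerns a different part of the molecule. Compound 2 thus stands at the upper of the two numbers, a difference from compound 1 that lies within the scatter. Compound 3 `Nc1cccc(Nc2nc3ccccc3nc2S(=O)(=O)c2ccc(F)cc2)c1` differs from compound 2 by fluoro in place of methoxy on an aromatic carbon. Going by the values given here, no measured step touches this part of the molecule; the step from compound 1 to compound 2 changed another group and stayed within the scatter, so it offers no guide to size or direction. Among the compounds with values here, with no comparable step to draw on, the estimated step from compound 2 to compound 3 is a 1.1-fold lower number from compound 2 to compound 3 (0.03 log units; within the scatter), nothing beyond the scatter either way. Compound 3 is therefore expected to give 8000 nM in this assay, within 3000 nM to 22000 nM.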

Compound 3, half-maximal inhibitory concentration: 1980 nM
Compound 3: the middle estimate sits 4.0-fold (0.61 log units) above what was measured, outside the stated range (below it).
By their numbers in this assay, from the lowest: compound 3; then compounds 1 and 2 (each within the scatter of the next).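

In this assay, for the compounds shown here, the change from 4-methoxyphenyl to 4-fluorophenyl gives a 4.3-fold lower number from compound 2 to compound 3 (0.64 log units; beyond the scatter), the first step in this short series to lie beyond the scatter. Going by these compounds alone, it shows that the read-out responds to the group at this position, para to a large group, something the only earlier step could not show: a 1.4-fold higher number from compound 1 to compound 2 (0.14 log units; within the scatter) changed another part of the molecule and stayed within the scatter. Nothing measured here bears on why the number falls, so the step stands as an observation only.

With methoxy and fluoro the only groups shown at this position, it remains open how chloro, methyl or trifluoromethyl would compare there. Going by these compounds, it is also open whether the same step would appear with the 3,5-dimethoxyphenyl group of compound 1, since fluoro appears here only alongside 3-aminophenyl.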